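The source may report more compounds than this note shows. Statements on the series, on what has been measured and on what is new or still open speak of the compounds shown alone.

Measured so far in a functional assay on MCF7 cells (Homo sapiens) for inhibition, read by MTT assay, with a stated time of 48 h, tested at 10 uM; a lower number here means less inhibition of growth, a higher number more inhibition of growth at the concentration tested:
compound 1 `Cc1oc2c([C@H]3CCN(C)C[C@H]3O)c(O)cc(O)c2c(=O)c1C(O)c1ccc(Cl)cc1` gives 6%
compound 2 `Cc1oc2c([C@H]3CCN(C)C[C@H]3O)c(O)cc(O)c2c(=O)c1C(O)c1c(F)cccc1Cl` gives 41%

Compound 2 holds the higher of the two values, and compound 1 lies beyond the scatter under it. Compound 3 `Cc1oc2c([C@H]3CCN(C)C[C@H]3O)c(O)cc(O)c2c(=O)c1C(O)c1ccc(F)cc1` has not yet been measured. It carries 4-fluorophenyl in place of 2-chloro-6-fluorophenyl on a saturated chain carbon bound to an aromatic carbon and an oxygen on a saturated carbon.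

Among the compounds with values here, one measured step bears on this change, at the same place: a number 35 percentage points higher from compound 1 to compound 2 (beyond the scatter), with 2-chloro-6-fluorophenyl in place of 4-chlorophenyl. The 4-fluorophenyl of compound 3 is closer by name to the 4-chlorophenyl of compound 1 than to the group of compound 2, so much of that large step is expected to be lost in this assay. No exchange of 4-chlorophenyl for 4-fluorophenyl has been measured, so the value of compound 1 at 6% is only a rough guide. The expected change is a large fall beyond the scatter, a number 29 percentage points lower from compound 2 to compound 3 (beyond the scatter). The estimate for compound 3 is 12%, with an expected range from 0% to 30%.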

Compound 3, percent growth inhibition at one concentration: 9%
Compound 3: middle estimate off by 3 percentage points, on the high side; measured number inside the range.
By their numbers in this assay, from the lowest: compounds 1 and 3 (each within the scatter of the next); then compound 2.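

In this assay, 4-fluorophenyl in place of 2-chloro-6-fluorophenyl on the saturated chain carbon gives a number 32 percentage points lower from compound 2 to compound 3 (beyond the scatter), so compound 2 now stands apart from two compounds, not one, and among these three no compound goes against the pairing of 2-chloro-6-fluorophenyl with the higher growth inhibition. Fluoro in place of chloro on an aromatic carbon gives a number 3 percentage points higher from compound 1 to compound 3 (within the scatter), so in this pair the exchange of one halogen for the other does not register in the read-out, and 4-chlorophenyl and 4-fluorophenyl cannot be told apart here. Nothing on hand explains why compound 2 stands apart from the other two.

Still open, going by these compounds, is whether the higher number of compound 2 needs both the chloro and the fluoro of 2-chloro-6-fluorophenyl, or whether one of them alone would carry it. Also open, on these data alone, is what plain phenyl or a methoxyphenyl would give on this carbon, and whether the hydroxy on the same carbon matters, as a ketone carbonyl in its place would show.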